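Pyridin-4-yl for 4-hydroxyphenyl on the saturated chain

The source may report more compounds than this note shows. Statements on the series, on what has been measured and on what is new or still open speak of the compounds shown alone.

Values so far in a physicochemical assay for lipophilicity, measured as octanol-water partition, at pH 7.4; on this read-out higher numbers stand for higher lipophilicity and lower numbers for lower lipophilicity:
compound 1 `CC(=O)N[C@H](C(=O)N1C[C@H](O)C[C@H]1C(=O)N[C@@H](CCc1ccc(Br)cc1)c1ccc(-c2scnc2C)cc1)C(C)(C)C` gives 4.08
compound 2 `CC(=O)N[C@H](C(=O)N1C[C@H](O)C[C@H]1C(=O)N[C@@H](CCC(=O)O)c1ccc(-c2scnc2C)cc1)C(C)(C)C` gives -0.44
compound 3 `CC(=O)N[C@H](C(=O)N1C[C@H](O)C[C@H]1C(=O)N[C@@H](CCc1ccc(O)cc1)c1ccc(-c2scnc2C)cc1)C(C)(C)C` gives 3.08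

Compound 3 stands second of the three, under compound 1 and well above compound 2. Compound 4 `CC(=O)N[C@H](C(=O)N1C[C@H](O)C[C@H]1C(=O)N[C@@H](CCc1ccncc1)c1ccc(-c2scnc2C)cc1)C(C)(C)C` carries pyridin-4-yl in place of 4-hydroxyphenyl on a saturated chain carbon, three bonds along the chain from an amide-type nitrogen and an aromatic carbon. For the measured compounds named here, no measured step makes this exchange. The closest evidence is hydroxy in place of bromo on an aromatic carbon, which gives a number 1.00 log units lower from compound 1 to compound 3 (beyond the scatter) and is modest. The two steps that remove the aromatic ring altogether are large, namely a number 4.52 log units lower from compound 1 to compound 2 (beyond the scatter) and a number 3.52 log units higher from compound 2 to compound 3 (beyond the scatter), but compound 4 keeps a six-membered aromatic ring, so these two set only an outer frame. Going by the values given here, a modest step is therefore expected in this assay, and it is expected to be downward, a direction that no measured step tests. The expected step is a number 0.68 log units lower from compound 3 to compound 4 (beyond the scatter) by this estimate. The estimate for compound 4 is 2.4, with 1.9 to 2.9 as the expected range.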

Compound 4, distribution coefficient: 2.7
Estimate against measurement, compound 4: 0.30 log units below, within the range that was stated.
By their numbers in this assay, from the lowest: compound 2; then compound 4; then compound 3; then compound 1.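

In this assay, this position now has a ring-for-ring exchange that keeps a six-membered aromatic ring on the chain: pyridin-4-yl in place of 4-hydroxyphenyl gives a number 0.38 log units lower from compound 3 to compound 4 (beyond the scatter), a modest step in the downward direction. The two other new steps place compound 4 within the span of the series, with a number 3.14 log units higher from compound 2 to compound 4 (beyond the scatter) and a number 1.38 log units lower from compound 1 to compound 4 (beyond the scatter), so pyridin-4-yl sits much closer to the 4-hydroxyphenyl compound than to the carboxy compound, while the step from the 4-bromophenyl compound is also large. No measurement shown here accounts for the size of any of these steps, and none can be assigned to the ring nitrogen or to the loss of the hydroxy group.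

The compounds shown leave open whether the step depends on where the nitrogen sits in the ring, as pyridin-3-yl or pyridin-2-yl on the same saturated chain carbon would show. They also leave open how this read-out responds to an amine such as piperidin-4-yl at this place, or to pyridin-4-yl carried on a longer chain.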